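Replacing one fluorinated group in compound 1

The source may report more compounds than this note shows. Statements on the series, on what has been measured and on what is new or still open speak of the compounds shown alone.

In a functional assay on LNCaP cells (Homo sapiens) for antiproliferative activity, read by propidium iodide staining, with a stated time of 96 h (on this read-out higher numbers stand for weaker inhibition and lower numbers for stronger inhibition), compound 1 (`CC(O)(COc1ccc(S(F)(F)(F)(F)F)cc1)C(=O)Nc1ccc(S(F)(F)(F)(F)F)cc1`) gives 9800 nM and compound 2 (`CC(O)(COc1ccc(OC(F)(F)F)cc1)C(=O)Nc1ccc(S(F)(F)(F)(F)F)cc1`) gives 18600 nM, so these two cannot be told apart. Compound 3 (`CC(O)(COc1ccc(C#N)cc1)C(=O)Nc1ccc(S(F)(F)(F)(F)F)cc1`) gives 100000 nM, well apart from both, which places compound 1 in the better pair.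

Compound 4 (`CC(O)(COc1ccc(S(F)(F)(F)(F)F)cc1)C(=O)Nc1ccc(C(F)(F)F)cc1`) is still unmeasured. Compound 1 carries its sulfur-bearing group twice, and compound 4 alters one copy: a group of 4 heavy atoms (1 carbon, 3 fluorine; no ring) in place of a group of 6 heavy atoms (5 fluorine, 1 sulfur; no ring), on an aromatic carbon (para to a large group).

All three measured steps alter the other copy, so they bear on this change only indirectly. Trifluoromethoxy there made little difference (a 1.9-fold higher number from compound 1 to compound 2 (0.28 log units; within the scatter)), whereas cyano made a large one (a 10-fold higher number from compound 1 to compound 3 (1.01 log units; beyond the scatter)). Trifluoromethyl resembles trifluoromethoxy more than cyano, so a small step is the likelier outcome, though no measured step touches this copy.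

The estimated step is a 1.5-fold higher number from compound 1 to compound 4 (0.18 log units; within the scatter) in this assay, with no change beyond the scatter expected. For compound 4 the expected value is 15000 nM, with an estimated range from 6000 nM to 40000 nM in this series.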

Compound 4, half-maximal inhibitory concentration: 11700 nM
For compound 4 the middle estimate is 1.3-fold (0.11 log units) above the measured one, within the range that was stated.
By their numbers in this assay, from the lowest: compounds 1, 4 and 2 (each within the scatter of the next); then compound 3.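

Until now every measured step had altered the other copy of the sulfur-bearing group. In this assay, among these compounds, the step to trifluoromethyl is the first to touch this copy, and it is a 1.2-fold higher number from compound 1 to compound 4 (0.08 log units; within the scatter), so this copy accepts that smaller fluorinated group with no change beyond the scatter. Nothing available explains why the number holds here.

Cyano gave a large step at the other copy, and whether this copy would answer that group in the same way stays open. Also open, as far as these compounds go, is what a group without fluorine, such as an amine, a carboxylic acid or a longer chain, would do on this aromatic carbon, and whether changing both copies at once would still leave the number in place.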